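The source may hold more compounds than are shown below. What is called first, only, known or untested is meant among the compounds shown, and "the series" means these compounds.

Working notes on the series. Compound 1 `CCCCSc1nsnc1[C@@H]1CN2CCC[C@H]1C2` gives 0.026 mg/kg in a functional assay on the whole organism for inhibition, with Mus musculus as the target (on this read-out higher numbers stand for an effect only at larger amounts of compound and lower numbers for an effect already at smaller amounts), compound 2 `CCCSc1nsnc1C1CN2CCC[C@H]1C2` gives 0.056 mg/kg in this assay, and compound 3 `CCCSc1nsnc1[C@@H]1CN2CCC[C@H]1C2` gives 0.17 mg/kg in this assay. Compound 3 thus stands highest of the three numbers, with compound 2 its nearest neighbour and compound 1 its furthest. Two measured steps end there: a 6.5-fold higher number from compound 1 to compound 3 (0.82 log units; beyond the scatter), and a 3.0-fold higher number from compound 2 to compound 3 (0.48 log units; beyond the scatter).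

Compound 4 `CCCSc1nsnc1[C@@H]1CN2CCC[C@@H]1C2` differs from compound 3 at a single stereocentre: the two compounds have the same atoms and bonds; at least one stereo element is drawn with a configuration in one of them and without one in the other: 1 of 3 stereo elements differ; a stereocentre at a saturated ring carbon is drawn R in compound 3 and S in compound 4. For the measured compounds named here, of the measured steps only the one from compound 2 bears on this change, because the fact that one of compounds 2 and 3 is drawn with a defined configuration and the other without, at the place where they differ leaves compound 2 consistent with material that carries both configurations at the saturated ring carbon. Where compound 2 holds the configuration of compound 4 together with that of compound 3, and its number sits below that of compound 3, the configuration of compound 4 on its own should give a lower number still. A downward step beyond the scatter in this assay is therefore expected, plausibly larger than the step seen from compound 2. Compound 4 is expected to give 0.03 mg/kg, estimated within 0.01 mg/kg to 0.1 mg/kg. The expected step is a 5.7-fold lower number from compound 3 to compound 4 (0.75 log units; beyond the scatter).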

Compound 4, dose for half-maximal effect: 2.2 mg/kg
Estimate against measurement, compound 4: 73-fold (1.87 log units) below; measured number above the stated range.
By their numbers in this assay, from the lowest: compound 1; then compound 2; then compound 3; then compound 4.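

In this assay, the ring stereocentre drawn R in compound 3 and S in compound 4 proves to matter more than any change seen so far in the series, with a 13-fold higher number from compound 3 to compound 4 (1.11 log units; beyond the scatter) exceeding both the chain step a 6.5-fold higher number from compound 1 to compound 3 (0.82 log units; beyond the scatter) and the stereo step a 3.0-fold higher number from compound 2 to compound 3 (0.48 log units; beyond the scatter). With atoms and bonds unchanged, this large rise can be set on the configuration at that one centre alone: the fact that one of compounds 3 and 4 is drawn with a defined configuration and the other without, at the place where they differ. The wider step a 39-fold higher number from compound 2 to compound 4 (1.59 log units; beyond the scatter) spans two stereo elements and isolates neither, but it shows that compound 2, drawn R at this centre like compound 3, does not hold the configuration of compound 4 there, so the undefined centre of compound 2 is a separate stereo element from the one changed here.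

The compounds shown leave open how the configuration at the centre drawn without one in compound 2 combines with the S configuration of compound 4. They also leave open whether the same large step appears with the butyl chain of compound 1 or with a longer chain such as hexyl on the sulfur.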